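Fluorophenyl shift on the shared core: outlook for compound 4

The source may report more compounds than this note shows. Statements on the series, on what has been measured and on what is new or still open speak of the compounds shown alone.

Compound 1 `Oc1ccccc1-c1cc(-c2cccc(F)c2)cc(-c2ccccc2O)n1`: in a functional assay on T47D cells (Homo sapiens) for inhibition (on this read-out lower numbers stand for stronger inhibition and higher numbers for weaker inhibition), compound 1 gives > 50000 nM, a limit of the assay and not a number.
Compound 2 `Oc1cccc(-c2cc(-c3cccc(F)c3)cc(-c3ccccc3O)n2)c1`: compound 2 gives > 50000 nM, again a limit.
Compound 3 `Oc1ccc(-c2cc(-c3ccccc3F)cc(-c3ccccc3O)n2)cc1`: compound 3 gives > 50000 nM, also a limit.

Compound 3 thus stands only at a limit, as do the two other values; see (the limit of > 50000 nM in this assay, at which 3 of the 3 values shown sit). Within the data shown here, the one measured step, a step that the two limits leave unreadable from compound 1 to compound 2, is unreadable between two limits. Compound 4 `Oc1ccc(-c2cc(-c3cccc(F)c3)cc(-c3ccccc3O)n2)cc1` differs from compound 3 by 3-fluorophenyl in place of 2-fluorophenyl on an aromatic carbon. Among the measured compounds shown here, no measured step bears on this change, so no readable step is expected beyond the scatter. Compound 4 is therefore estimated at 80000 nM, between 30000 nM and 300000 nM, most likely again a limit, giving an expected step that the limit leaves unreadable from compound 3 to compound 4.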

Compound 4, half-maximal inhibitory concentration: > 50000 nM
Compound 4: no number, only a limit (the forecaster's own chance of this, stated with the estimate: 85%); the middle value does not contradict the limit.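

Among these compounds, compound 4 sits at a limit, as do compound 1, compound 2 and compound 3, so no step between them can be read: the limit of > 50000 nM in this assay, at which 4 of the 4 values shown sit. The compounds shown leave open whether moving the hydroxyphenyl or fluorophenyl group on the shared core changes inhibition at all.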